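From 3-chlorophenyl to 4-fluorophenyl on compound 1

The source may hold more compounds than are shown below. What is called first, only, known or untested is meant among the compounds shown, and "the series" means these compounds.

Among the measured compounds shown here, in a functional assay on PC-3 cells (Homo sapiens) for inhibition, read by sulforhodamine B assay (on this read-out higher numbers stand for weaker inhibition of growth and lower numbers for stronger inhibition of growth), compound 1 `Cc1ccc2[nH]c(-c3ccc(-c4ccc(-c5cccc(Cl)c5)cc4)cc3)nc2c1` gives 2670 nM and stands lowest of the three compounds measured so far. Compound 3 `COc1ccc(-c2ccc(-c3ccc(-c4nc5c(O)cccc5[nH]4)cc3)cc2)cc1` gives 6610 nM and compound 2 `Clc1cccc(-c2ccc(-c3ccc(-c4nc5ccccc5[nH]4)cc3)cc2)c1` gives 33700 nM in the same test. Compound 4 `Cc1ccc2[nH]c(-c3ccc(-c4ccc(-c5ccc(F)cc5)cc4)cc3)nc2c1` is still unmeasured, and the change from compound 1 is 4-fluorophenyl in place of 3-chlorophenyl on an aromatic carbon with the rest of the structure kept. For the measured compounds named here, the only measured step, a 13-fold higher number from compound 1 to compound 2 (1.10 log units; beyond the scatter), is large, but it removes the methyl, which compound 4 retains. Going by the values given here, no measured step exchanges the 3-chlorophenyl group, so no shift beyond the scatter is expected in this assay and the range stays wide. The estimated step is a 1.2-fold higher number from compound 1 to compound 4 (0.08 log units; within the scatter) and carries that uncertainty. Compound 4 is expected at 3200 nM with a range from 1000 nM to 10000 nM around it.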

Compound 4, concentration for 50% growth inhibition: 100000 nM
Beside the measured number, compound 4's estimate is 31-fold (1.49 log units) below it; the whole stated range lies below it.
By their numbers in this assay, from the lowest: compound 1; then compound 3; then compound 2; then compound 4.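

In this assay, putting 4-fluorophenyl in place of 3-chlorophenyl on the shared core gives a 37-fold higher number from compound 1 to compound 4 (1.57 log units; beyond the scatter). Among the compounds shown here, the only earlier step, a 13-fold higher number from compound 1 to compound 2 (1.10 log units; beyond the scatter), concerned the methyl, whereas this one shows that growth inhibition also depends strongly on the substituted phenyl group. No measurement shown here accounts for this loss.

The halogen and its place on the ring change together, so their contributions remain unseparated. From the compounds shown here alone, how an amine or a carboxylic acid on this ring would behave also remains open.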